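A few compounds are considered here, and "the series" means these few. Any claim that something is new, unique, unknown or untested is made for them only; others in the source may bear on it.

In an in vitro functional assay on HEK285-7 cells for antagonist activity at prostaglandin D2 receptor 2 (Homo sapiens), read by BRET and beta-arrestin recruitment (a higher number here means a larger maximal response, a lower number a smaller maximal response), three compounds have been measured. Compound 1 `Nc1nc(-c2ccc(Cl)cc2)c(CC(=O)O)s1` gives 50%. Compound 2 `O=C(O)Cc1sc(C(c2ccccc2)c2ccc(F)cc2)nc1-c1ccc(Cl)cc1` gives 80%. Compound 3 `Nc1cc(-c2nc(C(c3ccc(F)cc3)c3ccc(F)cc3)sc2CC(=O)O)cc(F)n1` gives 30%, the smallest maximal response of the three, and its gaps to compound 1 and to compound 2 both lie beyond the usual scatter of repeated measurements.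

The next compound, compound 4 `Cc1cc(-c2nc(C(c3ccc(F)cc3)c3ccc(F)cc3)sc2CC(=O)O)ccn1`, differs from compound 3 in one place: 2-methylpyridin-4-yl in place of 2-amino-6-fluoropyridin-4-yl on an aromatic carbon. The shared core, with its carboxymethyl group and the large group, stays unchanged.

Among the measured compounds shown here, no measured pair shows this exact swap, and its effect in this assay is therefore unknown from the numbers at hand. Compound 3 carries an amino group and a fluorine that are absent in compound 2, and compound 2 reaches 80%; that hints at an upward move, though the two compounds also differ elsewhere. Compound 4 is expected to show a moderate rise, a number 15 percentage points higher from compound 3 to compound 4 (beyond the scatter). Compound 4 is estimated at 45%, between 25% and 70%.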

Compound 4, largest response reached (reported as efficacy), in percent of the reference or control that the assay uses: 80%
Estimate against measurement, compound 4: 35 percentage points below; the whole stated range lies below it.
By their numbers in this assay, from the lowest: compound 3; then compound 1; then compounds 2 and 4 (each within the scatter of the next).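

On this aromatic carbon of the shared core, the pyridine ring stays in place and only the groups on it change, yet this assay shows a number 50 percentage points higher from compound 3 to compound 4 (beyond the scatter). Among the compounds shown here, the maximal response is therefore sensitive to what the pyridine ring carries at this position, a point the earlier compounds could not show, as none of them formed a one-place pair. The entering 2-methylpyridin-4-yl has no hydrogen-bond donor and one acceptor, against one donor and two acceptors in the leaving 2-amino-6-fluoropyridin-4-yl, but nothing available explains why the response moves.

Going by these compounds, the swap removes an amino group and a fluorine and adds a methyl group all at once, so the share of each remains open. A plain pyridin-4-yl or a 2-aminopyridin-4-yl at this position would help separate these contributions.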